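Changing the Ring on the Carbon Double-Bonded to Nitrogen

A few compounds are considered here, and "the series" means these few. Any claim that something is new, unique, unknown or untested is made for them only; others in the source may bear on it.

Compound 1 `COc1cc(OC)c2c(=O)c(OCC(=O)N/N=C/c3sccc3C)c(-c3cc(OC)c(OC)c(OC)c3)oc2c1`: 4470 nM
Compound 2 `COc1cc(OC)c2c(=O)c(OCC(=O)N/N=C/c3ccc[nH]3)c(-c3cc(OC)c(OC)c(OC)c3)oc2c1`: 3750 nM

In a functional assay on MDA-MB-231 cells (Homo sapiens) for cytotoxicity, read by MTT assay, with a stated time of 38 h (a higher number here means a weaker inhibitor, a lower number a stronger inhibitor), compound 1 gives 4470 nM, while compound 2 gives 3750 nM. Going by the values given here, the two numbers sit within the usual scatter of one another, the only step between them being a 1.2-fold lower number from compound 1 to compound 2 (0.08 log units; within the scatter), so compound 2 cannot be set apart from compound 1 on these figures.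

Compound 3 `COc1cc(OC)c2c(=O)c(OCC(=O)N/N=C/c3ccccc3F)c(-c3cc(OC)c(OC)c(OC)c3)oc2c1` has not been measured. It differs from compound 2 in one place: 2-fluorophenyl in place of 1H-pyrrol-2-yl on a carbon with a double bond to nitrogen. Among the compounds with values here, the one step that bears on this change, a 1.2-fold lower number from compound 1 to compound 2 (0.08 log units; within the scatter), swapped one five-membered ring for another at the same carbon and stayed within the scatter. Moving to a six-membered ring of carbon only has no direct precedent here, so a step no larger than the scatter is expected for a 1.1-fold higher number from compound 2 to compound 3 (0.03 log units; within the scatter). Compound 3 is therefore estimated at 4000 nM, with a range from 1800 nM to 9000 nM.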

Compound 3, half-maximal inhibitory concentration: 3400 nM
Estimate against measurement, compound 3: 1.2-fold (0.07 log units) above, within the range that was stated.
By their numbers in this assay, from the lowest: compounds 3, 2 and 1 (each within the scatter of the next).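

Moving from a five-membered ring to a six-membered ring of carbon only gives a 1.1-fold lower number from compound 2 to compound 3 (0.04 log units; within the scatter) and, against the other five-membered ring, a 1.3-fold lower number from compound 1 to compound 3 (0.12 log units; within the scatter) in this assay. Here 2-fluorophenyl, with 0 hydrogen-bond donors, also replaces 1H-pyrrol-2-yl, which has 1, yet the step stays within the scatter, so neither ring size nor that donor separates these compounds on this carbon. No supporting evidence bears on why the three compounds cannot be told apart.

On these data alone, all three groups at this carbon are aromatic rings, so it remains open whether a ring bearing an amine or a carboxylic acid, or a longer chain of carbon atoms in place of the ring, would move the number beyond the scatter. As far as these compounds go, whether the same holds in other cell lines also remains open.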